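Notes on a coumarin series: fluoro to bromo swap

A few compounds are considered here, and "the series" means these few. Any claim that something is new, unique, unknown or untested is made for them only; others in the source may bear on it.

Measured so far:
- compound 1 `O=c1cc(O)c2ccc(OCc3cccc(F)c3)cc2o1`: 2090 nM
- compound 2 `COc1cc(=O)oc2cc(OCc3cccc(F)c3)ccc12`: 36.3 nM
- compound 3 `CCOc1cc(=O)oc2cc(OCc3cccc(F)c3)ccc12`: 263 nM

In an assay on isolated protein (strain Sprague-Dawley) for inhibition of Amine oxidase [flavin-containing] B (Rattus norvegicus), read by spectrophotometry, with a stated time of 5 min (a higher number here means a weaker inhibitor, a lower number a stronger inhibitor), compound 3 sits second highest of the three numbers. Its nearest neighbour is compound 2, the change being a 7.2-fold higher number from compound 2 to compound 3 (0.86 log units; beyond the scatter); its furthest is compound 1, with a 7.9-fold lower number from compound 1 to compound 3 (0.90 log units; beyond the scatter). Compound 4 `CCOc1cc(=O)oc2cc(OCc3cccc(Br)c3)ccc12` differs from compound 3 by bromo in place of fluoro on an aromatic carbon. For the measured compounds named here, none of the measured steps touches this position: a 58-fold lower number from compound 1 to compound 2 (1.76 log units; beyond the scatter) and a 7.9-fold lower number from compound 1 to compound 3 (0.90 log units; beyond the scatter) concern the oxygen on the aromatic ring of the shared core, not the halogen on the outer ring. There is therefore no shown step to size the change from; the expectation in this assay is a step not beyond the scatter, direction unknown, namely a 1.3-fold lower number from compound 3 to compound 4 (0.12 log units; within the scatter). Compound 4 is estimated at 200 nM, within 60 nM to 800 nM.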

Compound 4, half-maximal inhibitory concentration: 126 nM
Compound 4: the middle estimate sits 1.6-fold (0.20 log units) above what was measured; low and high end bracket the measured number.
By their numbers in this assay, from the lowest: compound 2; then compound 4; then compound 3; then compound 1.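

In this assay, for the compounds shown here, the swap from 3-fluorophenyl to 3-bromophenyl gives a 2.1-fold lower number from compound 3 to compound 4 (0.32 log units; beyond the scatter) and is the first measured change on the outer ring, as the earlier steps all concerned the oxygen on the shared core. The number therefore responds to the halogen here as well, though only modestly with the ethyl group kept in place. Nothing available accounts for this step.

From the compounds shown here alone, whether bromo for fluoro acts the same way on compound 2, with its methyl group, remains open. Going by these compounds, how chloro, a nitrile or an amine would compare at this place is also open.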